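Methoxy added to a weak benzyloxy triarylethylene

This account rests on a few compounds, and the source may have more. Where it says the series, first, only, none or still open, it means among the compounds named here.

Series notes. Measured in a functional assay on HeLa cells (Homo sapiens) for inhibition, read by trypan blue exclusion, with a stated time of 72 h (a lower number here means a stronger inhibitor of growth, a higher number a weaker inhibitor of growth), compound 1 `CC/C(=C(\c1ccc(NC(=O)C(C)C)cc1)c1ccc(OC)cc1)c1ccccc1` gives 10100 nM. Compound 2 `CC/C(=C(/c1ccccc1)c1ccc(NC(=O)C(C)C)cc1)c1ccc(OCc2ccccc2)cc1` gives only a limit in this assay, > 30000 nM, as recorded in the limit of > 30000 nM in this assay, at which 1 of the 2 values shown sits. Compound 2 therefore stands at the weak end of the numbers shown, with no numeric value of its own, while compound 1 is the only compound with a measured number.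

Compound 3 `CC/C(=C(\c1ccc(NC(=O)C(C)C)cc1)c1ccc(OC)cc1)c1ccc(OCc2ccccc2)cc1` is not yet measured. It differs from compound 2 by methoxy in place of hydrogen on an aromatic carbon. Going by the values given here, no measured step in this assay links the two compounds. The expectation is a small step in this assay, leaning towards stronger inhibition of growth, of size an at least 1.3-fold lower number from compound 2 to compound 3 (0.13 log units; that floor lies within the scatter), and possibly none beyond the scatter. Compound 3 is estimated at 22000 nM in this assay, with the range running from 7000 nM to 60000 nM.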

Compound 3, concentration for 50% growth inhibition: > 30000 nM
Compound 3 ended at the assay's limit; the forecaster's own chance of this, stated with the estimate: 40%; middle value at least 1.3-fold (0.13 log units) away from the limit.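

In this assay compound 3 gives > 30000 nM, which is a limit and not a number, and the step from compound 2, also held at a limit, cannot be read: the limit of > 30000 nM in this assay, at which 2 of the 3 values shown sit.

Adding methoxy to the benzyloxy compound therefore does not bring it into the measured range of this assay. Adding a benzyloxy group gives an at least 2.9-fold higher number from compound 1 to compound 3 (0.47 log units; beyond the scatter), the only readable step so far, and it shows weaker inhibition of growth with this group present.

As far as these compounds go, how far compound 2 and compound 3 lie beyond the limit remains open, so any effect of methoxy here remains unknown. Also open, from the compounds shown here alone, is whether an amine or a carboxylic acid in place of the benzyloxy group would return a measurable number.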